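This account rests on a few compounds, and the source may have more. Where it says the series, first, only, none or still open, it means among the compounds named here.

Measured compounds in a functional assay on CHO cells for agonist activity at Free fatty acid receptor 1 (Homo sapiens), read by FLIPR and calcium flux, with a stated time of 90 s, tested at 100 nM; a lower number here means a weaker effect, a higher number a stronger effect of the compound at the concentration tested:
compound 1, `Cc1cccc(C)c1-c1cccc(COc2ccc3c(c2)OCC3CC(=O)O)c1`, gives 62.6%
compound 2, `O=C(O)CC1COc2cc(OCc3cccc(N4CCCCC4)c3)ccc21`, gives 34.7%
compound 3, `O=C(O)CC1COc2cc(OCc3cccc(-n4cccc4)c3)ccc21`, gives 28.6%

Compound 3 stands lowest of the three numbers. Its nearest neighbour is compound 2, which sits within the scatter (a number 6.1 percentage points lower from compound 2 to compound 3 (within the scatter)), while compound 1 lies well beyond it (a number 34 percentage points lower from compound 1 to compound 3 (beyond the scatter)). The unmeasured compound 4, `Cc1ccc(C)n1-c1cccc(COc2ccc3c(c2)OCC3CC(=O)O)c1`, differs from compound 3 in one place: 2,5-dimethyl-1H-pyrrol-1-yl in place of 1H-pyrrol-1-yl on an aromatic carbon. The ring type is kept; methyl groups are added to it.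

Among the measured compounds shown here, two measured steps bear on this change. The step of a number 34 percentage points lower from compound 1 to compound 3 (beyond the scatter) was large, and there compound 1 carries 2,6-dimethylphenyl, a ring that bears methyl groups much as the new group in compound 4 does. The step of a number 6.1 percentage points lower from compound 2 to compound 3 (within the scatter) was within the scatter and shows that exchanging one nitrogen-linked ring for another moved the number little. Since compound 4 keeps the pyrrole of compound 3 but gains the methyl groups seen in compound 1, a rise of moderate size is expected in this assay, though compound 1 is only a partial guide. The expected step is a number 16.4 percentage points higher from compound 3 to compound 4 (beyond the scatter). Compound 4 is therefore estimated at 45%, with a range from 25% to 68%.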

Compound 4, a percentage reported as activity, at one concentration (the size of the read-out at that concentration, not a potency): 59.9%
Compound 4: the middle estimate sits 14.9 percentage points below what was measured, and the stated range covers the measured number.
By their numbers in this assay, from the lowest: compounds 3 and 2 (each within the scatter of the next); then compounds 4 and 1 (each within the scatter of the next).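

In this assay, among the compounds shown here, placing 2,5-dimethyl-1H-pyrrol-1-yl where 1H-pyrrol-1-yl stood gives a number 31.3 percentage points higher from compound 3 to compound 4 (beyond the scatter), so, unlike the earlier steps, which exchanged one ring type for another, this one shows that methyl groups alone, on an unchanged ring, can produce a large shift at this position. The methylated pyrrole also stands clear of piperidin-1-yl, with a number 25.2 percentage points higher from compound 2 to compound 4 (beyond the scatter), but it cannot be told apart from 2,6-dimethylphenyl, with a number 2.7 percentage points lower from compound 1 to compound 4 (within the scatter); among these four compounds, the two rings bearing methyl groups both give higher numbers than the two without them, and no compound shown goes against this. Nothing available here explains why the methyl groups have this effect.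

The compounds shown leave open whether a single methyl group on the pyrrole, as in 2-methyl-1H-pyrrol-1-yl, would be enough, and what ethyl groups or chlorine atoms would do in place of the two methyl groups. The read-out also gives only the size of the effect at one concentration, so these numbers tell which compounds have a stronger or weaker effect at that concentration and nothing about other concentrations.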